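The source may report more compounds than this note shows. Statements on the series, on what has been measured and on what is new or still open speak of the compounds shown alone.

Measured so far in an assay on membranes from Sf9 cells for displacement of a labelled ligand from histamine H2 receptor (Homo sapiens), read by scintillation counting, with a stated time of 60 min; on this read-out lower numbers stand for stronger inhibition and higher numbers for weaker inhibition:
compound 1 `Cc1nc(N)sc1CCCN/C(N)=N/C(=O)NCC(C)CCc1ccccc1`: 63.1 nM
compound 2 `Cc1nc(N)sc1CCCN/C(N)=N/C(=O)NC(C)c1ccc(Br)cc1`: 30.2 nM
compound 3 `Cc1nc(N)sc1CCCN/C(N)=N/C(=O)NC(c1ccccc1)C(C)C`: 35.5 nM

Compound 1 gives the highest of the three numbers. Compound 3 sits within the scatter of compound 1, so no order is drawn between those two; compound 2 gives a lower number than compound 1, and that gap lies beyond the scatter. Compound 4 `Cc1nc(N)sc1CCCN/C(N)=N/C(=O)NCC(C)CC1CCCCC1` is not yet measured. It differs from compound 1 in one place: cyclohexyl in place of benzyl on a saturated chain carbon, three bonds along the chain from an amide-type nitrogen. Among the compounds with values here, no step between two measured compounds covers this change, so nothing measured shows its size. The expected step in this assay is a 1.1-fold lower number from compound 1 to compound 4 (0.02 log units; within the scatter), small and in no firm direction, with the change expected to stay within the scatter. Compound 4 is expected to give 60 nM in this assay, with a range of 20 nM to 180 nM.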

Compound 4, inhibition constant: 70.8 nM
For compound 4 the middle estimate is 1.2-fold (0.07 log units) below the measured one, within the range that was stated.
By their numbers in this assay, from the lowest: compounds 2, 3, 1 and 4 (each within the scatter of the next, the first and the last beyond it).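

In this assay, cyclohexyl in place of benzyl on a saturated chain carbon, three bonds along the chain from an amide-type nitrogen, gives a 1.1-fold higher number from compound 1 to compound 4 (0.05 log units; within the scatter). At this position, then, a six-membered non-aromatic ring of carbon only is read the same as the aromatic ring, and an aromatic ring at this chain end is not required for binding in the nanomolar range seen for compound 1. No measurement at hand accounts for this step. Going by these compounds, whether an amine or a hydroxyl on the cyclohexyl ring, or a longer chain at this place, would give a step beyond the scatter remains open.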